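This account rests on a few compounds, and the source may have more. Where it says the series, first, only, none or still open, it means among the compounds named here.

Two members of the series have numbers in an in vitro functional assay on 1321-N1 cells for antagonist activity at transient receptor potential cation channel subfamily V member 1 (Homo sapiens), read by FLIPR and calcium flux; on this read-out lower numbers stand for lower potency and higher numbers for higher potency (the scale is a negative logarithm). Compound 1, `Cc1nc2ccc(NC(=O)c3ccc(-c4ccc(F)cc4)nc3C)cc2[nH]1`, gives 6 in this assay. Among the compounds with values here, compound 2, `Cc1nc(-c2ccc(F)cc2)ccc1C(=O)Nc1ccc2ncn(C)c2c1`, gives 6.7 in this assay, the higher of the two numbers; compound 1 sits lower by a gap beyond the scatter, though the two structures differ in more than one place and no single counted step connects them. Compound 3, `Cc1nc(-c2ccc(F)cc2)ccc1C(=O)Nc1ccc2nc[nH]c2c1`, remains to be measured in this assay. The change from compound 2 to compound 3 is hydrogen in place of methyl on an aromatic nitrogen. Within the data shown here, no measured pair isolates this change, so its size is unknown here. Among the measured compounds shown here, compound 1, the only measured compound with hydrogen on the ring nitrogen, sits lower, but other differences travel with it, and that gap cannot be read as the effect of the methyl alone. The expectation is a small decrease, a number 0.30 log units lower from compound 2 to compound 3 (within the scatter), within or near the scatter. Compound 3 is estimated at 6.4 in this assay, with a range from 5.8 to 7.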

Compound 3, negative logarithm of the antagonist equilibrium constant: 7.2
Estimate against measurement, compound 3: 0.80 log units below, outside the stated range (above it).
By their numbers in this assay, from the lowest: compound 1; then compound 2; then compound 3.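

In this assay the aromatic nitrogen of the five-membered aromatic ring now has a step of its own: hydrogen in place of methyl at this position gives a number 0.50 log units higher from compound 2 to compound 3 (beyond the scatter). This separates the change from the other differences between compound 1 and compound 2. A second single change, hydrogen in place of methyl on an aromatic carbon, gives a number 1.20 log units higher from compound 1 to compound 3 (beyond the scatter) and shows that the carbon position also responds to this swap, with hydrogen carrying the higher number at both positions in these two pairs. Nothing on hand accounts for either step.

From the compounds shown here alone, each position rests on a single pair, so it remains open whether the same steps would hold on a core with any other change, or whether hydrogen is the best group at either position. An ethyl group or a longer chain on the aromatic nitrogen, or an amine or a chlorine on the aromatic carbon, would show whether the numbers keep falling with any group larger than hydrogen or depend on the particular group.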